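Swapping a core substituent with the amine untouched

A few compounds are considered here, and "the series" means these few. Any claim that something is new, unique, unknown or untested is made for them only; others in the source may bear on it.

Measured compounds:
compound 1 `COc1cccc(CNCCCNc2ccnc3cc(Oc4ccccc4)ccc23)c1O`: 9.28
compound 2 `c1ccc(Oc2ccc3c(NCCCNCc4ccco4)ccnc3c2)cc1`: 9.28
compound 3 `COc1ccc(F)cc1CNCCCNc1ccnc2cc(Oc3ccccc3)ccc12`: 9.28

In a physicochemical assay for acid dissociation, compound 1 stands level with compounds 2 and 3. The steps of no change at the digits printed from compound 1 to compound 2 (within the scatter), no change at the digits printed from compound 1 to compound 3 (within the scatter) and no change at the digits printed from compound 2 to compound 3 (within the scatter) all sit within the scatter, each changing the group on a saturated chain carbon bound to an amine nitrogen. Compound 4 `COc1cccc(CNCCCNc2ccnc3cc(-c4ccc(C(F)(F)F)cc4)ccc23)c1O` differs from compound 1 elsewhere: 4-(trifluoromethyl)phenyl in place of phenoxy on an aromatic carbon. Among the measured compounds shown here, no measured step alters this part of the shared core, so the three steps bear on it only indirectly, by showing how little the read-out moved when the outer groups were exchanged. The expected step of a number 0.08 log units lower from compound 1 to compound 4 (within the scatter) is therefore small, with no clear direction. For compound 4 the estimate is 9.2, ranging from 8.8 to 9.6.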

Compound 4, acid dissociation constant: 9.47
For compound 4 the middle estimate is 0.27 log units below the measured one; low and high end bracket the measured number.
By their numbers in this assay, from the lowest: compounds 1, 2, 3 and 4 (each within the scatter of the next).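

Among the compounds shown here, this is the first exchange on an aromatic carbon of the shared core, as the earlier steps changed only the group on the chain. In this assay the exchange of phenoxy for 4-(trifluoromethyl)phenyl gives a number 0.19 log units higher from compound 1 to compound 4 (within the scatter) even though oxygen leaves and fluorine enters, so this one change at this position stays within the scatter. Nothing measured here explains this result.

From the compounds shown here alone, whether an amine or a carboxylic acid on this aromatic carbon would also stay within the scatter remains open. So does whether this exchange gives the same result with furan-2-yl or 5-fluoro-2-methoxyphenyl on the chain.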